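From 4-fluorophenyl to 2,4,6-trimethylphenyl on the sulfonyl sulfur

The source may hold more compounds than are shown below. What is called first, only, known or untested is meant among the compounds shown, and "the series" means these compounds.

Compound 1 `COC(=O)c1ccc(C2SCC(=O)N2c2ccc(N3CCN(Cc4cc(OC)c(OC)c(OC)c4)CC3)cn2)c(OC)c1` gives > 100000 nM
Compound 2 `COC(=O)c1ccc(C2SCC(=O)N2c2ccc(N3CCN(S(=O)(=O)c4ccc(F)cc4)CC3)cn2)c(OC)c1` gives > 100000 nM

In a functional assay on K562 cells (Homo sapiens) for antiproliferative activity, read by MTT assay and trypan blue exclusion, with a stated time of 72 h (on this read-out lower numbers stand for stronger inhibition and higher numbers for weaker inhibition), compound 2 gives > 100000 nM as a limit of the assay, not a number. Among the compounds with values here, the picture so far is the limit of > 100000 nM in this assay, at which 2 of the 2 values shown sit, and no step between measured compounds exists. Compound 3 `COC(=O)c1ccc(C2SCC(=O)N2c2ccc(N3CCN(S(=O)(=O)c4c(C)cc(C)cc4C)CC3)cn2)c(OC)c1` carries 2,4,6-trimethylphenyl in place of 4-fluorophenyl on a sulfonyl sulfur, a change counted as 2,4,6-trimethylphenyl in place of 4-fluorophenyl on a sulfonyl sulfur and made on the same core. In this assay no change beyond the scatter is expected, and the estimated step is a number no higher from compound 2 to compound 3 (the limit leaves the size open) as the working figure. Compound 3 is expected to give 100000 nM, with an estimated range of 40000 nM to 200000 nM as its likely span.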

Compound 3, half-maximal inhibitory concentration: 53500 nM
Compound 3: the middle estimate sits 1.9-fold (0.27 log units) above what was measured; the measured number falls inside the stated range.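

Within the data shown here, at the sulfonyl sulfur, 2,4,6-trimethylphenyl gives the first reading in this assay that is a number and not a limit. The change reads as an at least 1.8-fold lower number from compound 2 to compound 3 (0.27 log units; that floor lies within the scatter), so it cannot be said to go beyond the scatter. The step has only a floor, since one of its ends is a limit: the limit of > 100000 nM in this assay, at which 2 of the 3 values shown sit.

Going by these compounds, what a methyl or a 4-aminophenyl group on the sulfonyl sulfur would give in this assay stays open. The compounds shown also do not separate the loss of the fluorine from the gain of the methyl groups.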